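Halophenyl swap from compound 3 to compound 4

The source may report more compounds than this note shows. Statements on the series, on what has been measured and on what is new or still open speak of the compounds shown alone.

In a functional assay on Caco-2 cells (Homo sapiens) for inhibition, read by MTT assay, with a stated time of 48 h, tested at 10 uM (on this read-out higher numbers stand for more inhibition of growth at the one concentration tested and lower numbers for less inhibition of growth), compound 1 (`Cc1cc(=O)c2c(O)cc(OCc3ccc([N+](=O)[O-])cc3)c([C@H]3CCN(C)C[C@H]3O)c2o1`) gives 14% of inhibition and compound 2 (`Cc1cc(=O)c2c(O)c(CN3CCC(c4ccccc4)CC3)c(O)c([C@H]3CCN(C)C[C@H]3O)c2o1`) gives 21% of inhibition. Compound 3 (`Cc1oc2c([C@H]3CCN(C)C[C@H]3O)c(O)cc(O)c2c(=O)c1C(O)c1ccc(Cl)cc1`) gives 3% of inhibition and is the lowest of the three, beyond the scatter from both compound 1 and compound 2.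

Compound 4 (`Cc1oc2c([C@H]3CCN(C)C[C@H]3O)c(O)cc(O)c2c(=O)c1C(O)c1ccccc1Br`) differs from compound 3 in one place: 2-bromophenyl in place of 4-chlorophenyl on a saturated chain carbon bound to an aromatic carbon and an oxygen on a saturated carbon with 2-bromophenyl in place of 4-chlorophenyl on a saturated chain carbon bound to an aromatic carbon and an oxygen on a saturated carbon.

Among the measured compounds shown here, no measured pair isolates this change, so the numbers give no direct size for it. The closest guide is compound 3 at 3% of inhibition, which shares everything with compound 4 except the aryl group. The estimated step of a number 4 percentage points higher from compound 3 to compound 4 (within the scatter) is small and slightly upward, and it is not expected to go beyond the scatter in this assay at all. Compound 4 is expected at 7% (estimated range 0% to 18%).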

Compound 4, percent growth inhibition at one concentration: 7%
Beside the measured number, compound 4's estimate shows no gap at the digits printed; measured number inside the range.
By their numbers in this assay, from the lowest: compounds 3, 4, 1 and 2 (each within the scatter of the next, the first and the last beyond it).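

In this assay, among the compounds shown here, 2-bromophenyl in place of 4-chlorophenyl on a saturated chain carbon bound to an aromatic carbon and an oxygen on a saturated carbon gives a number 4 percentage points higher from compound 3 to compound 4 (within the scatter), the first direct reading of a change at this position. The swap alters the halogen and where it sits on the phenyl ring together, so this one step cannot assign a contribution to either. Nothing available accounts for the size of this step.

On these data alone, it remains open whether 2-chlorophenyl, 4-bromophenyl or unsubstituted phenyl would separate those two changes. Also open, as far as these compounds go, is whether a methoxy in place of the hydroxy on that chain carbon, or an amine or a carboxylic acid on the phenyl ring, would move the number beyond the scatter.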